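A few compounds are considered here, and "the series" means these few. Any claim that something is new, unique, unknown or untested is made for them only; others in the source may bear on it.

Going by the values given here, in a functional assay on MCF7 cells (Homo sapiens) for cytotoxicity, read by MTT assay, with a stated time of 96 h (a lower number here means a stronger inhibitor, a higher number a weaker inhibitor), compound 1 `COc1cc(C(=O)c2cn(-c3ccc(N)cc3)cc2-c2ccccc2)cc(OC)c1OC` gives 35 nM as the lowest of the three numbers so far. Compound 2 `COc1cc(C(=O)c2cn(-c3ccc(C)cc3)cc2-c2cccc([N+](=O)[O-])c2)cc(OC)c1OC` gives 210 nM as the highest, and compound 3 `COc1cc(C(=O)c2cn(-c3ccc(N)cc3)cc2-c2ccccc2Cl)cc(OC)c1OC` gives 83 nM in the middle, with its gaps to both others beyond the usual scatter.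

Compound 4 `COc1cc(C(=O)c2cn(-c3ccc(N)cc3)cc2-c2cccc([N+](=O)[O-])c2)cc(OC)c1OC` keeps the 4-aminophenyl group of compound 3 and differs by 3-nitrophenyl in place of 2-chlorophenyl on an aromatic carbon at one place, with 3-nitrophenyl in place of 2-chlorophenyl on an aromatic carbon.

Among the compounds with values here, one measured step bears directly on this change. Putting chloro in place of hydrogen on an aromatic carbon gave a 2.4-fold higher number from compound 1 to compound 3 (0.38 log units; beyond the scatter) and this modest rise suggests that losing the 2-chlorophenyl group could take a little of it back. Within the data shown here, compound 2 is the only tested compound with the 3-nitrophenyl group, but it lacks the 4-aminophenyl group, so its 210 nM is not a clean step and only warns against expecting a large gain. Among the measured compounds shown here, no measured step isolates the 3-nitrophenyl group, so the range must stay wide.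

The expected change is slightly downward, a 1.2-fold lower number from compound 3 to compound 4 (0.07 log units; within the scatter) in this assay and no step beyond the scatter is expected. Compound 4 is estimated at 70 nM with an expected range from 22 nM to 220 nM around that middle.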

Compound 4, half-maximal inhibitory concentration: 260 nM
Compound 4: middle estimate off by 3.7-fold (0.57 log units), on the low side; the whole stated range lies below it.
By their numbers in this assay, from the lowest: compound 1; then compound 3; then compounds 2 and 4 (each within the scatter of the next).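

In this assay, the aromatic group on the five-membered ring proves sensitive to what it carries: 3-nitrophenyl in place of 2-chlorophenyl gives a 3.1-fold higher number from compound 3 to compound 4 (0.50 log units; beyond the scatter), and nitro in place of hydrogen gives a 7.4-fold higher number from compound 1 to compound 4 (0.87 log units; beyond the scatter), a larger step than the one seen earlier for chloro, a 2.4-fold higher number from compound 1 to compound 3 (0.38 log units; beyond the scatter). Both substituents tested on this phenyl group therefore go with higher numbers than the bare phenyl group of compound 1, and the new result shows that the choice of substituent matters as well. With 3-nitrophenyl held constant, amino in place of methyl gives a 1.2-fold higher number from compound 2 to compound 4 (0.09 log units; within the scatter), so this pair shows no separation between the 4-aminophenyl group and its methyl counterpart, and no measurement at hand explains any of these steps.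

From the compounds shown here alone, it remains open whether the higher number follows the nitro group itself or its location on the phenyl group, since chloro and nitro stand at different places in these compounds. A nitrile, a methoxy group or a carboxylic acid on that phenyl group could help separate these two readings.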